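The source may hold more compounds than are shown below. What is called first, only, known or untested is meant among the compounds shown, and "the series" means these compounds.

Compound 2 `Clc1cccc(-c2nc(N3CCCCC3)c3nc[nH]c3n2)c1` carries piperidin-1-yl and 3-chlorophenyl on the shared core. In an assay on cells for displacement of a labelled ligand from adenosine receptor A1 (Homo sapiens), read by scintillation counting and radioligand binding, with a stated time of 60 min, tested at 10 uM (on this read-out higher numbers stand for more inhibition at the one concentration tested (going by the name of the read-out) and lower numbers for less inhibition), compound 2 gives > 80%, a limit of the assay. Compound 1 `CN1CCN(c2nc(-c3cccc(Cl)c3)nc3[nH]cnc23)CC1` differs from compound 2 by 4-methylpiperazin-1-yl in place of piperidin-1-yl on an aromatic carbon. In this assay compound 1 gives > 80%, which is also a limit. The step that the two limits leave unreadable from compound 2 to compound 1 is not readable because of the limit of > 80% in this assay, at which 3 of the 3 values shown sit.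

Compound 3 `Oc1ccc(-c2nc(N3CCCCC3)c3nc[nH]c3n2)cc1` differs from compound 2 by 4-hydroxyphenyl in place of 3-chlorophenyl on an aromatic carbon; this is the difference between the two cores. In this assay compound 3 gives > 80%, a limit. The step that the two limits leave unreadable from compound 2 to compound 3 is likewise not readable.

Compound 4 `CN1CCN(c2nc(-c3ccc(O)cc3)nc3[nH]cnc23)CC1` is not yet measured in this assay. It differs from compound 3 by 4-methylpiperazin-1-yl in place of piperidin-1-yl on an aromatic carbon. The change is of the same kind as that from compound 2 to compound 1, not the same: in compound 2 the place is meta to a 3-chlorophenyl group, in compound 3 it is meta to a 4-hydroxyphenyl group. The step that the limit leaves unreadable from compound 3 to compound 4 is expected to be small, resting on a step that the two limits leave unreadable from compound 2 to compound 1 giving no readable loss. Compound 4 is expected to give 88% in this assay, most likely again as a limit.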

Compound 4, a percentage reported as inhibition, at one concentration (the size of the read-out at that concentration, not a potency): > 80%
Compound 4 gave a limit, no number; the forecaster's own chance of this, stated with the estimate: 80%; the middle value is on the limit's open side.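

In this assay compound 4 gives > 80%, which is a limit. The steps to compound 4 from compound 3 and from compound 1 cannot be read, because all four compounds share one limit: the limit of > 80% in this assay, at which 4 of the 4 values shown sit.

The compounds shown leave open how 4-methylpiperazin-1-yl compares with piperidin-1-yl, and 4-hydroxyphenyl with 3-chlorophenyl, in this assay.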